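Cyclohexyl for Naphthalen-1-yl: A Solubility Expectation for Compound 4

A few compounds are considered here, and "the series" means these few. Any claim that something is new, unique, unknown or untested is made for them only; others in the source may bear on it.

Compound 2 `COc1ccc(F)cc1CNCCCNc1ccnc2cc(-c3cccc4ccccc34)ccc12` and compound 3 `c1coc(CNCCCNc2ccnc3cc(-c4cccc5ccccc45)ccc23)c1` share a core and differ in one place, (furan-2-yl in place of 5-fluoro-2-methoxyphenyl on a saturated chain carbon bound to an amine nitrogen). In a physicochemical assay for solubility, with a stated time of 18 h, at pH 7.4 (on this read-out higher numbers stand for higher solubility and lower numbers for lower solubility), compound 2 gives 32000 nM, while compound 3 gives 32000 nM, so that no change at the digits printed from compound 2 to compound 3 (within the scatter). Compound 1 `COc1ccc(F)cc1CNCCCNc1ccnc2cc(C3CCCCC3)ccc12` comes from compound 2 through a single change, (cyclohexyl in place of naphthalen-1-yl on an aromatic carbon); in this assay compound 1 gives 4200 nM, and a 7.6-fold lower number from compound 2 to compound 1 (0.88 log units; beyond the scatter). Compound 4 `c1coc(CNCCCNc2ccnc3cc(C4CCCCC4)ccc23)c1` carries the same change on the core of compound 3, (cyclohexyl in place of naphthalen-1-yl on an aromatic carbon). The step from compound 3 to compound 4 is expected to be of similar size to that earlier one, a 7.6-fold lower number from compound 3 to compound 4 (0.88 log units; beyond the scatter), because the earlier step was a 7.6-fold lower number from compound 2 to compound 1 (0.88 log units; beyond the scatter). Compound 4 is therefore estimated at 4200 nM, within a range from 1500 nM to 12000 nM.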

Compound 4, solubility: 4200 nM
Beside the measured number, compound 4's estimate shows no gap at the digits printed; low and high end bracket the measured number.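

In this assay, cyclohexyl in place of naphthalen-1-yl gives a 7.6-fold lower number from compound 3 to compound 4 (0.88 log units; beyond the scatter), matching in size a 7.6-fold lower number from compound 2 to compound 1 (0.88 log units; beyond the scatter), and with cyclohexyl in place the furan-2-yl change gives no change at the digits printed from compound 1 to compound 4 (within the scatter), just as it did with naphthalen-1-yl present. The change therefore carried over intact from the core of compound 2 to the core of compound 3, but this is a single pair of cores in a single assay and does not show that it would carry to other cores in the series. Nothing shown here speaks to why the number falls with this change.

The compounds shown leave open whether a piperidine or a phenyl on that aromatic carbon would behave like cyclohexyl or like naphthalen-1-yl. They also leave open whether the step would keep its size on a core with a longer chain carrying the amine.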